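From 4-methoxyphenyl to 3-chlorophenyl on a shared core

The source may report more compounds than this note shows. Statements on the series, on what has been measured and on what is new or still open speak of the compounds shown alone.

Three measured compounds share one core and differ only in the substituted phenyl group on an amide-type nitrogen. In a functional assay on T47D cells (Homo sapiens) for inhibition, read by CCK-8 assay, with a stated time of 72 h, tested at 10 uM (on this read-out higher numbers stand for more inhibition of growth at the one concentration tested and lower numbers for less inhibition of growth), compound 3 `COc1ccc(NC(=O)C2(C(=O)Nc3ccc(Nc4ncc5cc(C(=O)N(C)C)n(C6CCCC6)c5n4)cc3)CC2)cc1` gives 96.1%. Compound 1 `Cc1cccc(NC(=O)C2(C(=O)Nc3ccc(Nc4ncc5cc(C(=O)N(C)C)n(C6CCCC6)c5n4)cc3)CC2)c1`, carrying 3-methylphenyl, gives 95.3%, and compound 2 `CN(C)C(=O)c1cc2cnc(Nc3ccc(NC(=O)C4(C(=O)Nc5cccc(O)c5)CC4)cc3)nc2n1C1CCCC1`, carrying 3-hydroxyphenyl, gives 83.7%. Compound 3 and compound 1 cannot be told apart, since the step is a number 0.8 percentage points higher from compound 1 to compound 3 (within the scatter). Compound 2 is clearly separated from compound 3, with a step of a number 12.4 percentage points higher from compound 2 to compound 3 (beyond the scatter).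

The next compound is compound 4 `CN(C)C(=O)c1cc2cnc(Nc3ccc(NC(=O)C4(C(=O)Nc5cccc(Cl)c5)CC4)cc3)nc2n1C1CCCC1`, which has 3-chlorophenyl in place of 4-methoxyphenyl on an amide-type nitrogen. Among the compounds with values here, no chlorinated compound has been measured yet, so any forecast rests on analogy. The closest guide is compound 1, whose 3-methylphenyl and the 4-methoxyphenyl of compound 3 gave a number 0.8 percentage points higher from compound 1 to compound 3 (within the scatter). The only clear drop came with hydroxy in place of methyl, a number 11.6 percentage points lower from compound 1 to compound 2 (beyond the scatter), and compound 4 carries no hydroxy. Going by compound 1 at 95.3%, no change beyond the scatter is expected in this assay. The expected step is a number 3.1 percentage points lower from compound 3 to compound 4 (within the scatter). For compound 4 the estimate is 93%, with an expected range from 82% to 100%.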

Compound 4, percent growth inhibition at one concentration: 92.6%
For compound 4 the middle estimate is 0.4 percentage points above the measured one; low and high end bracket the measured number.
By their numbers in this assay, from the lowest: compounds 2, 4, 1 and 3 (each within the scatter of the next, the first and the last beyond it).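

In this assay, a chlorine on this phenyl group on the amide-type nitrogen can't be told apart from either earlier well-performing group: the comparison with 4-methoxyphenyl gives a number 3.5 percentage points lower from compound 3 to compound 4 (within the scatter), and the comparison with the methyl group gives a number 2.7 percentage points lower from compound 1 to compound 4 (within the scatter). So this position accepts a third substituent without a clear loss, and 3-chlorophenyl, counted with no hydrogen-bond acceptor, performs indistinguishably from 4-methoxyphenyl, counted with one, while the comparison with hydroxy gives a number 8.9 percentage points higher from compound 2 to compound 4 (within the scatter), which means that compound 4, unlike compound 1 and compound 3, isn't clearly separated from the hydroxy compound. Nothing shown here offers an explanation for any of these results.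

Going by these compounds, it remains open whether a basic amine, a carboxylic acid or a nitrile on this phenyl ring would keep the same level of growth inhibition or would fall clearly below it. With only one concentration tested, the compounds shown also leave open whether compound 1, compound 3 and compound 4 would separate from one another at lower concentrations.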